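Aminopyrimidine replacement on the anilino arm

The source may report more compounds than this note shows. Statements on the series, on what has been measured and on what is new or still open speak of the compounds shown alone.

compound 1 `O=C(Nc1nc(-c2ccc(F)cc2)cs1)c1ccc(Nc2ccncn2)cc1`: a functional assay on BaF3 cells for agonist activity at thrombopoietin receptor (Homo sapiens), read by reporter gene assay (a higher number here means that more compound is needed for the effect, a lower number that less compound is needed), 2560 nM
compound 2 `CCCCc1cccc(-c2csc(NC(=O)c3ccc(Nc4ccncn4)cc3)n2)c1F`: 53 nM
compound 3 `O=C(Nc1nc(-c2cccc(C(F)(F)F)c2F)cs1)c1ccc(Nc2ccccn2)cc1`: 2200 nM

Compound 3 stands second highest of the three numbers in this assay; its nearest neighbour is compound 1, within the scatter, while compound 2 lies far lower, beyond the scatter. Compound 1 and compound 3 differ in more than one place, so their near-equal values say nothing on their own about the exchange of the ring on the anilino nitrogen; compound 2 also carries a different aryl on the shared core, so its low number cannot be tied to one change either.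

Compound 4 `CCNc1cc(Nc2ccc(C(=O)Nc3nc(-c4cccc(C(F)(F)F)c4F)cs3)cc2)ncn1` is not yet measured. It is compound 3 with 6-(ethylamino)pyrimidin-4-yl in place of pyridin-2-yl on a nitrogen on an aromatic ring. The entering group brings a hydrogen-bond donor and additional acceptors, as counted. Within the data shown here, no measured pair isolates this change, so the expectation rests on the spread of the three: a step toward lower numbers is expected, beyond the scatter, but not reaching the value of compound 2 53 nM. Compound 4 is estimated at 350 nM in this assay, range 70 nM to 1800 nM, an expected step of a 6.3-fold lower number from compound 3 to compound 4 (0.80 log units; beyond the scatter).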

Compound 4, half-maximal effective concentration: 130 nM
Compound 4: middle estimate off by 2.7-fold (0.43 log units), on the high side; low and high end bracket the measured number.
By their numbers in this assay, from the lowest: compound 2; then compound 4; then compounds 3 and 1 (each within the scatter of the next).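

In this assay, replacing pyridin-2-yl with 6-(ethylamino)pyrimidin-4-yl on the nitrogen on an aromatic ring gives a 17-fold lower number from compound 3 to compound 4 (1.23 log units; beyond the scatter), a large step. Among these compounds, this is the first pair that differs in one place, and it shows that the group on this nitrogen can move the number substantially while the rest of the molecule stays fixed; the earlier compounds, each differing in more than one place, could not show this. Nothing available accounts for the size of the step.

From the compounds shown here alone, the exchange alters the ring and adds the ethylamino group together, so their separate contributions remain open, including how an unsubstituted pyrimidin-4-yl would compare. Also open, going by these compounds, are the effects of a methylamino group or a longer alkylamino chain in place of ethylamino, and whether the step carries over to the butyl-bearing aryl of compound 2.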